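A few compounds are considered here, and "the series" means these few. Any claim that something is new, unique, unknown or untested is made for them only; others in the source may bear on it.

Of the compounds shown here, three built on one shared core have been tested in an assay on isolated protein for agonist activity at Bile acid receptor (Homo sapiens), read by AlphaScreen, with a stated time of 30 min; a higher number here means a larger maximal response, a lower number a smaller maximal response. Compound 1, `COc1ccc(C2SC(C)C(=O)Nc3c2c(C)nn3-c2ccccc2C)c(OC)c1`, gives 63%. Compound 3, `Cc1nn(-c2ccccc2Cl)c2c1C(c1ccc(Oc3ccccc3)cc1)SC(C)C(=O)N2`, gives 57%. Compound 2, `COc1cccc(-c2ccc([C@H]3S[C@@H](C)C(=O)Nc4c3c(C)nn4-c3ccccc3C)cc2)c1`, gives 41%, which is the lowest of the three numbers: compound 3 stands nearest, higher by a gap beyond the usual scatter, and compound 1 stands furthest away, also higher by more than the scatter. No two of these measured compounds differ in only a single place, so none of the gaps among them can be tied to one structural change.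

Compound 4, `COc1ccccc1-c1ccc([C@H]2S[C@@H](C)C(=O)Nc3c2c(C)nn3-c2ccccc2C)cc1`, has not yet been measured. It differs from compound 2 in one place: 2-methoxyphenyl in place of 3-methoxyphenyl on an aromatic carbon. The two compounds hold the same atoms, joined differently, so the whole difference is the methoxyphenyl group named above.

Among the measured compounds shown here, because no measured pair shows the effect of such a swap, the size of the step is open. The step in this assay is expected to be modest, estimated as a number 6 percentage points higher from compound 2 to compound 4 (within the scatter), most likely within the scatter or only slightly beyond it. Compound 4 is therefore expected to give about 47%, with a range from 30% to 64%.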

Compound 4, largest response reached (reported as efficacy), in percent of the reference or control that the assay uses: 50%
Estimate against measurement, compound 4: 3 percentage points below; the measured number falls inside the stated range.
By their numbers in this assay, from the lowest: compounds 2, 4, 3 and 1 (each within the scatter of the next, the first and the last beyond it).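

Among the compounds shown here, replacing 3-methoxyphenyl with 2-methoxyphenyl, on an aromatic carbon para to a large group, gives the first comparison in this assay between compounds that differ in only one place: the maximal response is a number 9 percentage points higher from compound 2 to compound 4 (within the scatter) for this change. The two compounds hold the same atoms, joined differently, so this single pair shows that the two methoxyphenyl groups cannot be told apart at this position in this read-out. No measurement of another kind is available to explain the step or to show how this change acts on the receptor.

The compounds shown leave open whether a different group at this place, such as 4-methoxyphenyl, a hydroxyphenyl ring, an aminophenyl ring or a benzoic acid group, would move the maximal response beyond the usual scatter. They also leave open whether the same swap would give a similar step on the core of compound 3, which carries a chlorine where compound 2 and compound 4 carry a methyl group.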